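The compounds below may be only part of what the source reports. "The series", "measured", "known", "first", "only" and "open" are said of these compounds alone.

Of the compounds shown here, three have been tested in an assay for inhibition of 17-beta-hydroxysteroid dehydrogenase type 1 (Homo sapiens), read by HPLC, with a stated time of 10 min, tested at 1 uM; on this read-out higher numbers stand for more inhibition at the one concentration tested (going by the name of the read-out) and lower numbers for less inhibition. Compound 1 `O=C(c1ccc(F)c(O)c1)c1ccc2cc(O)ccc2n1` gives 20%. Compound 2 `C=C(c1ccc(F)c(O)c1)c1cccc(-c2cccc(O)c2F)n1` gives 88%. Compound 3 `N#Cc1ccc2ccc(C(=O)c3ccc(F)c(O)c3)nc2c1` is reported as "not active" (no number reported), so no single number marks where it stands, only that it showed no appreciable inhibition at the tested concentration. Compound 4 `O=C(c1ccc(F)c(O)c1)c1ccc2ccc(-c3nnn[nH]3)cc2n1` is the next compound, not yet measured. It differs from compound 3 in one place: 1H-tetrazol-5-yl in place of cyano on an aromatic carbon. For the measured compounds named here, with no measured pair showing what this exchange does, any step from compound 3 in this assay can only be guessed, and a modest rise, not far beyond the scatter, seems more likely than a fall from a starting point reported as not active. Compound 4 is expected to give about 20%, within a range of 0% to 50%.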

Compound 4, a percentage reported as inhibition, at one concentration (the size of the read-out at that concentration, not a potency): "not active" (no number reported)
The entry for compound 4 holds no number; the estimate stays without a comparison.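

For the compounds shown here, compound 3 and compound 4 are both reported only as not active in this assay, without a number, so no step between them can be read. The compounds shown leave open whether exchanging cyano for 1H-tetrazol-5-yl changes inhibition at all. No measurement here offers an explanation.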